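Trifluoromethyl on a phenyl ring: expectations for compound 3

This account rests on a few compounds, and the source may have more. Where it says the series, first, only, none or still open, it means among the compounds named here.

Measured in a functional assay on HepG2 cells (Homo sapiens) for cytotoxicity, read by MTT assay, with a stated time of 48 h; a lower number here means a stronger inhibitor, a higher number a weaker inhibitor:
- compound 1 `O=C(CSc1ccc(Br)cc1)N1N=C(c2cc3ccccc3oc2=O)C[C@@H]1c1ccccc1C(F)(F)F`: 17900 nM
- compound 2 `O=C(CSc1ccc(Br)cc1)N1N=C(c2cc3ccccc3oc2=O)C[C@@H]1c1ccccc1`: 14500 nM

Among the compounds with values here, only two numbers exist so far, and compound 2 at 14500 nM sits within the scatter of compound 1 at 17900 nM. The next compound, compound 3 `O=C(CSc1ccc(Br)cc1)N1N=C(c2cc3ccccc3oc2=O)C[C@@H]1c1ccc(C(F)(F)F)cc1`, changes compound 2 by trifluoromethyl in place of hydrogen on an aromatic carbon. Within the data shown here, one measured step bears on this, a 1.2-fold lower number from compound 1 to compound 2 (0.09 log units; within the scatter), which exchanges the same two groups at a different aromatic carbon. That step stayed within the scatter, so no step beyond the scatter is expected in this assay, though one example is thin evidence. The expected change is a 1.1-fold higher number from compound 2 to compound 3 (0.04 log units; within the scatter). For compound 3 the estimate is 16000 nM, with an expected range of 9000 nM to 28000 nM.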

Compound 3, half-maximal inhibitory concentration: 12700 nM
Compound 3: the middle estimate sits 1.3-fold (0.10 log units) above what was measured, within the range that was stated.
By their numbers in this assay, from the lowest: compounds 3, 2 and 1 (each within the scatter of the next).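

In this assay, placing trifluoromethyl para to a large group gives a 1.1-fold lower number from compound 2 to compound 3 (0.06 log units; within the scatter) and so, like the earlier exchange on the same ring, leaves the number within the scatter. Moving the group from 2-(trifluoromethyl)phenyl to 4-(trifluoromethyl)phenyl gives a 1.4-fold lower number from compound 1 to compound 3 (0.15 log units; within the scatter) and so shows no readable effect of its place on the ring. Nothing available accounts for how close these three compounds lie. Going by these compounds, it remains open whether an amine or a carboxylic acid at this place would produce a step beyond the scatter.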